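Aryl substituent change from compound 2 to compound 3

The source may report more compounds than this note shows. Statements on the series, on what has been measured and on what is new or still open speak of the compounds shown alone.

Measured so far:
compound 1 `C#Cc1ccc(NC(=O)CCc2cccc3c2B(O)OC3)cc1`: 6600 nM
compound 2 `COc1ccc(NC(=O)CCc2cccc3c2B(O)OC3)cc1`: 850 nM

In a functional assay on MDA-MB-231 cells (Homo sapiens) for antiproliferative activity, read by MTT assay, with a stated time of 72 h (on this read-out higher numbers stand for weaker inhibition and lower numbers for stronger inhibition), compound 1 gives 6600 nM and compound 2 gives 850 nM, the lowest of the two numbers shown. Among the compounds with values here, the only measured step, a 7.8-fold lower number from compound 1 to compound 2 (0.89 log units; beyond the scatter), shows that the group on this aromatic carbon matters beyond the scatter. Compound 3 `CC(C)(C)OC(=O)NCc1ccc(NC(=O)CCc2cccc3c2B(O)OC3)cc1` carries ((tert-butoxycarbonyl)amino)methyl in place of methoxy on an aromatic carbon. Within the data shown here, no measured step involves the entering group, so its direction is open; a step of modest size is expected. Compound 3 is expected to give about 1500 nM in this assay, within 400 nM to 6000 nM. The expected step, a 1.8-fold higher number from compound 2 to compound 3 (0.25 log units; within the scatter), is an estimate only.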

Compound 3, half-maximal inhibitory concentration: 1300 nM
Compound 3: the middle estimate sits 1.2-fold (0.06 log units) above what was measured; the measured number falls inside the stated range.
By their numbers in this assay, from the lowest: compounds 2 and 3 (each within the scatter of the next); then compound 1.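

The step of a 1.5-fold higher number from compound 2 to compound 3 (0.18 log units; within the scatter) in this assay shows that this carbon, para to a large group, can carry ((tert-butoxycarbonyl)amino)methyl, with 9 heavy atoms, and stay level with methoxy, with 2. With a 5.1-fold lower number from compound 1 to compound 3 (0.71 log units; beyond the scatter) as a second step, compound 1 with ethynyl stands apart from both other compounds. No evidence on hand explains these steps.

Open, going by these compounds, is whether a free aminomethyl group or a carboxylic acid on this carbon would stay level with compound 2. Also open, on these data alone, is how a longer chain would read here.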